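This account rests on a few compounds, and the source may have more. Where it says the series, first, only, none or still open, it means among the compounds named here.

Measured so far:
compound 1 `CC(C)C(Nc1nccs1)c1ccc(-c2ccc3cccc(F)c3c2)[nH]c1=O`: in an ADME assay on microsomes from liver (Mus musculus) for metabolic stability (a lower number here means that the compound disappears faster, a higher number that the compound lasts longer), compound 1 gives 0.0733 h
compound 2 `CC(C)C(c1noc(=O)[nH]1)c1ccc(-c2ccc3cccc(F)c3c2)[nH]c1=O`: in this assay compound 2 gives > 3 h, a limit of the assay and not a number
compound 3 `CCC(CC)(c1nnc[nH]1)c1ccc(-c2ccc3cccc(F)c3c2)[nH]c1=O`: in this assay compound 3 gives 0.447 h

Compound 2 stands at the limit of this assay; its half-life is known only as a limit (the limit of > 3 h in this assay, at which 1 of the 3 values shown sits), so no exact starting point is available for the step to compound 4. The unmeasured compound 4 `CC(C)C(Nc1nnc[nH]1)c1ccc(-c2ccc3cccc(F)c3c2)[nH]c1=O` differs from compound 2 in one place: a group of 6 heavy atoms (2 carbon, 4 nitrogen; one five-membered aromatic ring with 3 hetero atoms) in place of a group of 6 heavy atoms (2 carbon, 2 nitrogen, 2 oxygen; one five-membered aromatic ring with 3 hetero atoms), on a saturated chain carbon bound to an aromatic carbon and a saturated chain carbon. Within the data shown here, one measured step bears on this position, an at least 40-fold higher number from compound 1 to compound 2 (1.61 log units; beyond the scatter), a large gain that went with the ring now leaving. Compound 3 carries a different five-membered ring with 3 hetero atoms at the same place and gives 0.447 h. With an amino link like that entering in compound 4, compound 1 gives 0.0733 h.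

The step to compound 4 is therefore expected to run downward, beyond the scatter: an at least 3.7-fold lower number from compound 2 to compound 4 (0.57 log units; beyond the scatter). For compound 4 the expected half-life in this assay is 0.8 h, with a range from 0.25 h to 3 h.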

Compound 4, half-life: 2.42 h
Beside the measured number, compound 4's estimate is 3.0-fold (0.48 log units) below it; low and high end bracket the measured number.
By their numbers in this assay, from the lowest: compound 1; then compound 3; then compound 4. At a limit, above all of these: compound 2.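

In this assay, exchanging 1,3-thiazol-2-yl for 4H-1,2,4-triazol-3-yl on the amine nitrogen gives a 33-fold higher number from compound 1 to compound 4 (1.52 log units; beyond the scatter), so the amino link as such does not tie this series to the short half-life of compound 1; the ring on that nitrogen carries a large part of the outcome. Compound 2 stands at a limit of the assay and not at a number: the limit of > 3 h in this assay, at which 1 of the 4 values shown sits. The change at the saturated chain carbon reads an at least 1.2-fold lower number from compound 2 to compound 4 (0.09 log units; that floor lies within the scatter), so the (4H-1,2,4-triazol-3-yl)amino group is not shown to fall short of the ring it replaces, although a larger true gap is not excluded.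

On these data alone, the real size of that gap stays open. Also open, as far as these compounds go, is whether a tetrazole or an imidazole on the amine nitrogen, or a cyclopropyl group on the saturated chain carbon, would keep the half-life of compound 4.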